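The source may hold more compounds than are shown below. What is called first, only, known or untested is meant among the compounds shown, and "the series" means these compounds.

Working notes on the series. In a functional assay on MV4-11 cells (Homo sapiens) for antiproliferative activity, read by resazurin assay, with a stated time of 72 h (a lower number here means a stronger inhibitor of growth, a higher number a weaker inhibitor of growth), compound 2 `CC(=O)N1CCCN(c2cccc(Nc3nccc(-c4c[nH]c5ncccc45)n3)c2)CC1` gives 20 nM, the second highest of three numbers. Compound 3 `CN1CCN(c2cccc(Nc3nccc(-c4c[nH]c5ncccc45)n3)c2)CC1` gives 5 nM and compound 1 `CC(=O)N1CCN(c2ccc(Nc3nccc(-c4c[nH]c5cccnc45)n3)cc2)CC1` gives 420 nM, so compound 2 sits between the two.

Compound 4 `CC(=O)N1CCCN(c2cccc(Nc3nccc(-c4cnc5n(C)cccc4-5)n3)c2)CC1` keeps the 4-acetyl-1,4-diazepan-1-yl group of compound 2 and changes one group on an aromatic carbon of the six-membered aromatic ring with 2 nitrogen: a group of 10 heavy atoms (8 carbon, 2 nitrogen; one five-membered aromatic ring with 1 hetero atom, one six-membered aromatic ring with 1 hetero atom) in place of a group of 9 heavy atoms (7 carbon, 2 nitrogen; one five-membered aromatic ring with 1 hetero atom, one six-membered aromatic ring with 1 hetero atom), on an aromatic carbon. The hydrogen-bond donor count of that group falls, and the acceptor count rises.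

Among the measured compounds shown here, the only measured single-place step, a 4.0-fold lower number from compound 2 to compound 3 (0.60 log units; beyond the scatter), concerns the 4-acetyl-1,4-diazepan-1-yl group and not the group exchanged here, so it serves only as a rough scale for this assay. For the measured compounds named here, compound 1 differs from compound 2 in more than one place and gives no clean step. All three measured compounds retain a hydrogen-bond donor in this group, so none of them tests its loss, and the direction rests on the structural change alone.

A higher number, beyond the scatter and larger than the modest measured step, is expected, though with wide uncertainty. The expected change is a 15-fold higher number from compound 2 to compound 4 (1.18 log units; beyond the scatter). For compound 4 the estimate is 300 nM, with an expected range from 60 nM to 1500 nM.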

Compound 4, concentration for 50% growth inhibition: 24 nM
The estimate for compound 4 lay 13-fold (1.10 log units) above the measured number, outside the stated range (below it).
By their numbers in this assay, from the lowest: compound 3; then compounds 2 and 4 (each within the scatter of the next); then compound 1.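

In this assay, the exchange on the aromatic carbon next to the ring nitrogen gives a 1.2-fold higher number from compound 2 to compound 4 (0.08 log units; within the scatter), so this position accepts the entering group, with 0 hydrogen-bond donors and 2 hydrogen-bond acceptors, in place of the leaving group, with 1 hydrogen-bond donor and 1 hydrogen-bond acceptor, without a change that can be separated from the scatter. Among the compounds shown here, compound 4 is the first compound to test the loss of that donor, and with the 4-acetyl-1,4-diazepan-1-yl group held constant, the donor proves unnecessary for growth inhibition at this level in this assay. Nothing available explains why the exchange is tolerated.

For the compounds shown here, it remains open whether the entering group is tolerated equally alongside the 4-methylpiperazin-1-yl group, which gave the only measured step beyond the scatter. Also open, from the compounds shown here alone, is how much larger the entering group can become at this position, for example with an ethyl group, a longer chain or a chain ending in an amine on its five- or six-membered ring.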